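The source may report more compounds than this note shows. Statements on the series, on what has been measured and on what is new or still open speak of the compounds shown alone.

Series notes. In an ADME assay on Vero cells (Chlorocebus sabaeus) for cytotoxicity, read by MTT assay, with a stated time of 72 h (on this read-out lower numbers stand for higher toxicity in this test and higher numbers for lower toxicity in this test), compound 1 `CCO/N=C1\C(=O)N(CCCOc2ccc3oc(-c4ccc(OC)cc4)c(C(=O)OCC)c3c2)c2ccc(OC)cc21` gives 32 ug/mL. Compound 2 `CCOC(=O)c1c(-c2ccc(OC)cc2)oc2ccc(OCCCCCN3C(=O)C(=O)c4cc(F)ccc43)cc12` gives 512 ug/mL in this assay. Compound 3 `CCO/N=C1\C(=O)N(CCCCCOc2ccc3oc(-c4ccc(OC)cc4)c(C(=O)OCC)c3c2)c2ccc(OC)cc21` gives 16 ug/mL in this assay, the lowest of the three numbers shown; compound 1 lies nearest to it, and that gap falls within the scatter, while compound 2 lies furthest, with a gap beyond the scatter. Among the measured compounds shown here, no pair of measured compounds differs in only one place, so no measured step is available to describe.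

Compound 4 `CCO/N=C1\C(=O)N(CCCCCOc2ccc3oc(-c4ccc(OC)cc4)c(C(=O)OCC)c3c2)c2ccc(F)cc21` has not yet been measured in this assay. It differs from compound 3 in a single place: fluoro in place of methoxy on an aromatic carbon.

With no measured step of this kind in the set, the expectation rests on compound 3 and its 16 ug/mL, taken as the anchor. The expected step of a 1.5-fold higher number from compound 3 to compound 4 (0.18 log units; within the scatter) is small and carries no direction that would reach beyond the scatter. Compound 4 is therefore expected to give 24 ug/mL in this assay, estimated within a range from 8 ug/mL to 80 ug/mL.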

Compound 4, half-maximal cytotoxic concentration: 32 ug/mL
Compound 4: middle estimate off by 1.3-fold (0.12 log units), on the low side, within the range that was stated.
By their numbers in this assay, from the lowest: compounds 3, 1 and 4 (each within the scatter of the next); then compound 2.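

In this assay, among the compounds shown here, fluoro in place of methoxy on an aromatic carbon gives a 2.0-fold higher number from compound 3 to compound 4 (0.30 log units; within the scatter), the first single-place step, and it stays within the scatter. At this place, on a six-membered aromatic ring of carbon only that is part of a fused system of two rings, the change removes the hydrogen-bond acceptor counted for methoxy, with no effect on this read-out that can be told from the scatter. Nothing available bears on why compound 3 and compound 4 read alike.

Going by these compounds, whether other groups at this place, such as an amine, a carboxylic acid or chloro, would also stay within the scatter remains open. One step also cannot show whether the same swap behaves alike on the chain of compound 1.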